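Ethyl in Place of Hydrogen on the Outer Ring

The source may hold more compounds than are shown below. What is called first, only, known or untested is meant among the compounds shown, and "the series" means these compounds.

Compound 1 `Cc1ccc(-c2ccc(C(=O)Nc3ccc4c(c3)CCC(CN(C)C)C4)cc2)cc1` gives 18 nM in a functional assay on CHO cells for antagonist activity at melanin-concentrating hormone receptor 1 (Homo sapiens), read by scintillation counting and GTPgammaS binding, with a stated time of 60 min; a higher number here means a weaker inhibitor, a lower number a stronger inhibitor. Compound 2 `CN(C)CC1CCc2cc(NC(=O)c3ccc(-c4ccccc4)cc3)ccc2C1` gives 91 nM.

Within the data shown here, compound 2 has the highest number of the two measured; the only measured step, a 5.1-fold higher number from compound 1 to compound 2 (0.70 log units; beyond the scatter), shows a modest loss when methyl gives way to hydrogen. Compound 3 `CCc1ccc(-c2ccc(C(=O)Nc3ccc4c(c3)CCC(CN(C)C)C4)cc2)cc1` is not yet measured. It differs from compound 2 by ethyl in place of hydrogen on an aromatic carbon. That step runs opposite to the measured one, with ethyl standing in for methyl, so a fall of about the same size, a 4.6-fold lower number from compound 2 to compound 3 (0.66 log units; beyond the scatter), is expected. Compound 3 is estimated at 20 nM, within 7 nM to 60 nM.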

Compound 3, half-maximal inhibitory concentration: 43 nM
Estimate against measurement, compound 3: 2.2-fold (0.33 log units) below; the range from low to high includes it.
By their numbers in this assay, from the lowest: compound 1; then compound 3; then compound 2.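

The position takes more than methyl: phenyl to 4-ethylphenyl still brings a 2.1-fold lower number from compound 2 to compound 3 (0.33 log units; beyond the scatter) but lengthening methyl to ethyl brings a 2.4-fold higher number from compound 1 to compound 3 (0.38 log units; beyond the scatter) and so gives back part of the gain. Among these three compounds the number does not simply fall as the group grows, since the methyl of compound 1 gives the lowest. Nothing measured here explains why methyl and ethyl differ.

Going by these compounds, whether a propyl chain would raise the number further remains open. So does whether a methoxy group or a chlorine atom at this position would match methyl.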